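Changing two stereocentres in compound 2

A few compounds are considered here, and "the series" means these few. Any claim that something is new, unique, unknown or untested is made for them only; others in the source may bear on it.

- Compound 1 `COC1=C(Br)[C@H](O)[C@@]2(C=C1Br)CC(C(=O)NCCCCCNC(=O)C1=NO[C@]3(C=C(Br)C(=O)[C@@H](Br)[C@@H]3O)C1)=NO2` gives 4500 nM
- Compound 2 `O=C(NCCCCCNC(=O)C1=NO[C@]2(C=C(Br)C(=O)[C@@H](Br)[C@@H]2O)C1)C1=NO[C@]2(C=C(Br)C(=O)[C@@H](Br)[C@@H]2O)C1` gives 2000 nM
- Compound 3 `COC1=C(Br)[C@H](O)[C@@]2(C=C1Br)CC(C(=O)NCCCCCNC(=O)C1=NO[C@]3(C=C(Br)C(=O)[C@@H]4O[C@@H]43)C1)=NO2` gives 10700 nM

All three values come from a functional assay on A549 cells (Homo sapiens) for cytotoxicity, read by sulforhodamine B assay; on this read-out higher numbers stand for weaker inhibition of growth and lower numbers for stronger inhibition of growth. Compound 2 has the lowest number, and compound 1 and compound 3 both lie above it by more than the usual scatter. Compound 4 `O=C(NCCCCCNC(=O)C1=NO[C@]2(C=C(Br)C(=O)[C@H](Br)[C@@H]2O)C1)C1=NO[C@]2(C=C(Br)C(=O)[C@H](Br)[C@@H]2O)C1` is a stereoisomer of compound 2, with the change (the two compounds have the same atoms and bonds and differ only in configuration as drawn: 2 of 6 stereo elements differ; a stereocentre at a saturated ring carbon is drawn S in compound 2 and R in compound 4; a stereocentre at a saturated ring carbon is drawn S in compound 2 and R in compound 4). Going by the values given here, no measured pair here tests a change of configuration alone, so the data offer no direct guide. With compound 2 already lowest at 2000 nM, a small move toward weaker inhibition seems likeliest. The expected step of a 1.4-fold higher number from compound 2 to compound 4 (0.15 log units; within the scatter) may stay within the scatter. Compound 4 is estimated at 2800 nM, within an expected range of 1000 nM to 8000 nM.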

Compound 4, concentration for 50% growth inhibition: 2400 nM
Beside the measured number, compound 4's estimate is 1.2-fold (0.07 log units) above it; low and high end bracket the measured number.
By their numbers in this assay, from the lowest: compounds 2, 4 and 1 (each within the scatter of the next, the first and the last beyond it); then compound 3.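

In this assay, changing two stereocentres at saturated ring carbons from S to R gives a 1.2-fold higher number from compound 2 to compound 4 (0.08 log units; within the scatter). Going by these compounds alone, this is the first pair here that tests configuration alone, and at these two stereocentres the assay does not tell the two forms apart. The comparison is a clean one: the fact that compounds 2 and 4 differ only in the configuration as drawn

On these data alone, it remains open whether the other stereocentres can change as freely, or whether this holds for an unsymmetrical compound such as compound 1. As far as these compounds go, the effect of an amine or a longer chain in place of the linking chain also remains unknown.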